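Bromo on the Phenyl Ring: From Compound 3 to Compound 4

The source may hold more compounds than are shown below. What is called first, only, known or untested is meant among the compounds shown, and "the series" means these compounds.

Compound 1 `C=C1CC[C@@H]2[C@](C)(CO)[C@H](O)CC[C@@]2(C)[C@@H]1/C=C/C1=C/C(=C/c2ccc(N(C)C)cc2)OC1=O`: 60.6%
Compound 2 `C=C1CC[C@@H]2[C@](C)(CO)[C@H](O)CC[C@@]2(C)[C@@H]1/C=C/C1=C/C(=C/c2ccco2)OC1=O`: 49.6%
Compound 3 `C=C1CC[C@@H]2[C@](C)(COC(=O)c3cccnc3)[C@H](OC(=O)c3cccnc3)CC[C@@]2(C)[C@@H]1/C=C/C1=C/C(=C\c2ccccc2)OC1=O`: 100%

In an assay on isolated protein for inhibition of Maltase-glucoamylase (Homo sapiens), tested at 100 uM (a higher number here means more inhibition at the concentration tested (going by the name of the read-out), a lower number less inhibition), compound 3 gives the highest of the three numbers, 100%, and its distances to compound 1 and to compound 2 are both beyond the scatter. Within the data shown here, the only measured step, a number 11 percentage points lower from compound 1 to compound 2 (beyond the scatter), concerns an exchange of the whole aromatic ring and does not match the change now considered. Compound 4 `C=C1CC[C@@H]2[C@](C)(COC(=O)c3cccnc3)[C@H](OC(=O)c3cccnc3)CC[C@@]2(C)[C@@H]1/C=C/C1=C/C(=C\c2cccc(Br)c2)OC1=O` differs from compound 3 by bromo in place of hydrogen on an aromatic carbon. Among the measured compounds shown here, no measured step bears on this single addition. Compound 3 already stands at the top of the scale of the read-out. Compound 4 is therefore expected to show a step of about a number 5 percentage points lower from compound 3 to compound 4 (within the scatter), with no room upward. The estimate for compound 4 is 95%, between 80% and 100%.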

Compound 4, a percentage reported as inhibition, at one concentration (the size of the read-out at that concentration, not a potency): 100%
The estimate for compound 4 lay 5 percentage points below the measured number; low and high end bracket the measured number.
By their numbers in this assay, from the lowest: compound 2; then compound 1; then compounds 3 and 4 (each within the scatter of the next).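

In this assay the change from phenyl to 3-bromophenyl gives no change at the digits printed from compound 3 to compound 4 (within the scatter) and so shows that this aromatic carbon, meta to a large group, accepts a bromine atom with no loss in the number. Since the read-out already stands at the top of its scale, any gain from the bromo could not appear here. Nothing at hand explains this result. Still open, from the compounds shown here alone, is whether an amine or a carboxylic acid at this same place would hold the number there, and whether the bromo would separate from hydrogen at a lower test concentration.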